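The source may report more compounds than this note shows. Statements on the series, on what has been measured and on what is new or still open speak of the compounds shown alone.

Compound 1 `O=C(Nc1ccc(C2=CCNCC2)cc1)c1ccc(-c2ccc(Cl)cc2)o1` gives 6500 nM in an ADME assay on SW1353 cells (Homo sapiens) for cytotoxicity, read by a luciferase reporter, with a stated time of 30 min; a lower number here means that less compound is tolerated, a higher number that more compound is tolerated
Compound 2 `O=C(Nc1ccc(N2CCNCC2)cc1)c1cccc(-c2ccc(Cl)cc2)n1` gives > 10000 nM as a limit
Compound 3 `CN(C(=O)c1ccc(-c2ccc(Cl)cc2)o1)c1ccc(N2CCNCC2)cc1` gives > 20000 nM as a limit

Compound 3 has only a limit, > 20000 nM and no number. Among the compounds with values here, compound 2 is the one other compound that ends in a limit, so only compound 1 offers a true reading.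

Compound 4 `Cn1ccnc1CN(C(=O)c1ccc(-c2ccc(Cl)cc2)o1)c1ccc(N2CCNCC2)cc1` has not been measured yet. It carries 1-methyl-1H-imidazol-2-yl in place of hydrogen on a saturated chain carbon bound to an amide-type nitrogen and so the methyl of compound 3 becomes (1-methyl-1H-imidazol-2-yl)methyl.

Within the data shown here, no two measured compounds differ in one place only, which leaves the size of this step in this assay open. A modest shift towards less compound tolerated is expected, and a shift no larger than the scatter is just as possible. The low end of the expectation leans on compound 1 with 6500 nM as a reading within range. The estimated change is an at least 1.3-fold lower number from compound 3 to compound 4 (0.12 log units; that floor lies within the scatter) and it remains an expectation. For compound 4 the estimate is 15000 nM with an expected range from 6000 nM to 30000 nM in this assay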

Compound 4, half-maximal cytotoxic concentration: > 20000 nM
Compound 4: no number, only a limit; the forecaster's own chance of this, stated with the estimate: 50%; middle value at least 1.3-fold (0.12 log units) from the limit.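

Compound 3 and compound 4 both end in a limit rather than a number in this assay, and the step between them cannot be read. The compounds shown leave open whether changing methyl to (1-methyl-1H-imidazol-2-yl)methyl shifts the tolerated concentration at all, and by how much.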